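The source may report more compounds than this note shows. Statements on the series, on what has been measured and on what is new or still open speak of the compounds shown alone.

In a functional assay on A-375 cells (Homo sapiens) for antiproliferative activity, read by MTT assay, with a stated time of 24 h (a higher number here means a weaker inhibitor, a lower number a stronger inhibitor), compound 1 `COc1cc(OC)c(-c2coc3cc(OCc4ccccc4)ccc3c2=O)cc1OC`, which carries a benzyl group on an oxygen of the shared core, gives 1640 nM. Compound 2 `COc1cccc(C(=O)Oc2ccc3c(=O)c(-c4cc(OC)c(OC)cc4OC)coc3c2)c1`, with (3-methoxyphenyl)carbonyl on that oxygen, gives > 10000 nM, which is a limit of the assay and not a number. Compound 3 `COc1cc(OC)c(-c2coc3cc(OCc4cccc(F)c4)ccc3c2=O)cc1OC`, the 3-fluorobenzyl analogue, gives 1300 nM, level with compound 1 within the scatter. Compound 4 `COc1cc(OC)c(-c2coc3cc(OCc4cccc(C(F)(F)F)c4)ccc3c2=O)cc1OC` has trifluoromethyl in place of fluoro on an aromatic carbon. Within the data shown here, the closest precedent is fluoro in place of hydrogen on an aromatic carbon, which gave a 1.3-fold lower number from compound 1 to compound 3 (0.10 log units; within the scatter). The larger steps, an at least 6.0-fold higher number from compound 1 to compound 2 (0.78 log units; beyond the scatter) and an at least 7.6-fold lower number from compound 2 to compound 3 (0.88 log units; beyond the scatter), exchange the whole group on the oxygen, so they bear less directly on this smaller change, which keeps the benzyl framework. No change beyond the scatter is therefore expected in this assay. The expected result is a 1.1-fold higher number from compound 3 to compound 4 (0.03 log units; within the scatter). Compound 4 is estimated at 1400 nM, with an expected range of 550 nM to 3800 nM.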

Compound 4, half-maximal inhibitory concentration: 1140 nM
Beside the measured number, compound 4's estimate is 1.2-fold (0.09 log units) above it, within the range that was stated.
By their numbers in this assay, from the lowest: compounds 4, 3 and 1 (each within the scatter of the next). At a limit, above all of these: compound 2.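

At the aromatic carbon that holds fluoro in compound 3, trifluoromethyl takes its place without a clear change in this assay: a 1.1-fold lower number from compound 3 to compound 4 (0.06 log units; within the scatter). Measured against the unsubstituted benzyl group, trifluoromethyl also leaves the reading level, with a 1.4-fold lower number from compound 1 to compound 4 (0.16 log units; within the scatter), so this assay does not separate hydrogen, fluoro and trifluoromethyl at this carbon across compounds 1, 3 and 4. Among these compounds, exchanging the whole group on the oxygen remains the only change here beyond the scatter, with an at least 8.7-fold lower number from compound 2 to compound 4 (0.94 log units; beyond the scatter), a step that starts from a limit of the assay and not from a number.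

As far as these compounds go, whether an amine, a carboxylic acid or a longer chain at this carbon would stay level with these three remains open. Nothing in the data given explains why the three substituents read alike.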